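A few compounds are considered here, and "the series" means these few. Any claim that something is new, unique, unknown or untested is made for them only; others in the source may bear on it.

Two compounds carry the same core and differ only in the group on a saturated ring carbon. Compound 1 `O=c1oc2ccccc2cc1C1=NN(c2ccccc2)[C@@H](c2cccc([N+](=O)[O-])c2)C1` bears a 3-nitrophenyl there; compound 2 `Cc1ccc([C@H]2CC(c3cc4ccccc4oc3=O)=NN2c2ccccc2)cc1` bears a 4-methylphenyl. In a functional assay on the whole organism (strain albino) for inhibition, with Rattus norvegicus as the target, read by paw edema, with stated times of 1 h and 4 h, at a dose of 200 mg/kg by the oral route (a higher number here means more inhibition at the dose given (going by the name of the read-out), a lower number less inhibition), compound 1 gives 31.2% and compound 2 gives 38%. For the measured compounds named here, these are the only two numbers measured, and the step of a number 6.8 percentage points higher from compound 1 to compound 2 (within the scatter) lies within the scatter, so the two compounds cannot be told apart on this read-out.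

Compound 3 `O=c1oc2ccccc2cc1C1=NN(c2ccccc2)[C@@H](c2ccccc2[N+](=O)[O-])C1` is the next step from compound 2. The change is 2-nitrophenyl in place of 4-methylphenyl on a saturated ring carbon. Going by the values given here, only one measured step bears on it, the exchange of a nitrophenyl for a methylphenyl between compound 1 and compound 2, and that step was within the scatter. Compound 1, which also carries a nitrophenyl on the same ring carbon, gives 31.2%. On this evidence compound 3 is expected to land close to both measured values, with the step of a number 6 percentage points lower from compound 2 to compound 3 (within the scatter) expected to stay within the scatter. The estimate for compound 3 in this assay is 32%, with a range from 21% to 44%.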

Compound 3, a percentage reported as inhibition, in the whole organism at one dose (the size of the read-out at that dose, not a potency): 26.6%
Beside the measured number, compound 3's estimate is 5.4 percentage points above it; low and high end bracket the measured number.
By their numbers in this assay, from the lowest: compounds 3, 1 and 2 (each within the scatter of the next, the first and the last beyond it).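

In this assay, the group on this saturated ring carbon now makes a readable difference: 2-nitrophenyl in place of 4-methylphenyl gives a number 11.4 percentage points lower from compound 2 to compound 3 (beyond the scatter) and is the only step among these compounds that lies beyond the scatter, although compound 1 lies within the scatter of both compound 2 and compound 3. Among the two nitrophenyl compounds, 2-nitrophenyl in place of 3-nitrophenyl gives a number 4.6 percentage points lower from compound 1 to compound 3 (within the scatter) and so leaves them indistinguishable on this read-out, which means that a shift of the nitro group around the ring has no readable effect here. No measurement at hand offers an explanation for the step from the methylphenyl to the nitrophenyl compound.

Every group shown at this carbon is a substituted phenyl ring, so it remains open how a plain phenyl, an aminophenyl, a hydroxyphenyl or a saturated ring such as cyclohexyl would behave there. On these data alone, with a single oral dose behind each number, it is also open whether the gap between compound 2 and compound 3 would persist at other doses.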